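The source may report more compounds than this note shows. Statements on the series, on what has been measured and on what is new or still open speak of the compounds shown alone.

Measured in an assay for inhibition of steroid 17-alpha-hydroxylase/17,20 lyase (Homo sapiens), tested at 0.2 uM; on this read-out higher numbers stand for a stronger effect at the one concentration tested and lower numbers for a weaker effect:
compound 1 `Fc1ccc(-c2ccc3c(-c4cccnc4)cccc3c2)cc1` gives 2%
compound 2 `Fc1ccc(-c2ccc3c(-c4ccncc4)cccc3c2)cc1` gives 1%

Both numbers are small and sit within the scatter of each other, the step being a number 1 percentage points lower from compound 1 to compound 2 (within the scatter). Compound 3 `COc1ccc2cc(-c3ccc(F)cc3)ccc2c1-c1cccnc1` differs from compound 1 by a single change: methoxy in place of hydrogen on an aromatic carbon. Among the measured compounds shown here, no measured step touches this change; the one step known swaps the pyridyl group, not a hydrogen for methoxy, so it gives no guide to direction. For the measured compounds named here, with both measured numbers low and the only known step within the scatter, compound 3 is expected to stay near compound 1, with a step of a number 1 percentage points higher from compound 1 to compound 3 (within the scatter). For compound 3 the estimate is 3%, between 0% and 15%.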

Compound 3, a percentage reported as inhibition, at one concentration (the size of the read-out at that concentration, not a potency): 6%
The estimate for compound 3 lay 3 percentage points below the measured number; measured number inside the range.
By their numbers in this assay, from the lowest: compounds 2, 1 and 3 (each within the scatter of the next).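

In this assay, placing methoxy in place of hydrogen, ortho to the pyridin-3-yl group, gives a number 4 percentage points higher from compound 1 to compound 3 (within the scatter). Among the compounds shown here, this is the first view of this position, and it shows that adding methoxy here produces no step beyond the scatter, with all the numbers still small. No measured evidence bears on this result.

As far as these compounds go, whether an amine, a hydroxyl group or a carboxylic acid at this position would give a step beyond the scatter stays open. Also open, from the compounds shown here alone, is whether methoxy would act the same way alongside the pyridin-4-yl group of compound 2.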